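The source may hold more compounds than are shown below. What is called first, only, known or untested is meant among the compounds shown, and "the series" means these compounds.

Measured so far:
compound 1, `COc1ccc2cc(C(C)c3nnc4n3N=C(c3ccc([N+](=O)[O-])cc3)CS4)ccc2c1` — 14700 nM
compound 2, `COc1ccc2cc(C(C)c3nnc4n3N=C(c3ccc(OC(F)(F)F)cc3)CS4)ccc2c1` — 16000 nM

Both numbers come from a functional assay on Huh-7 cells (Homo sapiens) for inhibition, read by sulforhodamine B assay, with a stated time of 72 h; on this read-out lower numbers stand for stronger inhibition and higher numbers for weaker inhibition. Compound 2 has the highest number of the two, and its nearest neighbour is compound 1 at a 1.1-fold higher number from compound 1 to compound 2 (0.04 log units; within the scatter), a step that stays within the scatter, so the two compounds are best read as indistinguishable.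

Compound 3, `COc1ccc2cc(C(C)c3nnc4n3N=C(c3ccc(Br)cc3)CS4)ccc2c1`, has not yet been measured. It differs from compound 2 at one place: bromo in place of trifluoromethoxy on an aromatic carbon. Among the measured compounds shown here, the only measured step that bears on this position is the one from compound 1 to compound 2, which also swapped one group on the same aromatic carbon and gave a 1.1-fold higher number from compound 1 to compound 2 (0.04 log units; within the scatter). That step did not move the number beyond the scatter, which suggests that this position tolerates different groups without much effect on this assay.

On that basis compound 3 is expected to sit close to compound 2, with a step of a 1.1-fold lower number from compound 2 to compound 3 (0.03 log units; within the scatter), and no direction beyond the scatter is expected. The estimate for compound 3 in this assay is 15000 nM, with a range from 6000 nM to 40000 nM.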

Compound 3, half-maximal inhibitory concentration: 9300 nM
Compound 3: the middle estimate sits 1.6-fold (0.21 log units) above what was measured; the measured number falls inside the stated range.
By their numbers in this assay, from the lowest: compounds 3, 1 and 2 (each within the scatter of the next).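

In this assay, swapping the five-heavy-atom trifluoromethoxy for bromo, a single heavy atom, on the same aromatic carbon gives a 1.7-fold lower number from compound 2 to compound 3 (0.24 log units; within the scatter), and this step stays within the scatter. Swapping nitro for bromo on that carbon gives a 1.6-fold lower number from compound 1 to compound 3 (0.20 log units; within the scatter), also within the scatter, so three different groups on this carbon, para to a large group, now cannot be told apart in this assay, where the earlier pair offered only two groups and a single step. Nothing available here accounts for why these groups read alike.

On these data alone, what an amine, a carboxylic acid or a longer chain would do on this carbon stays open, and so does the plain phenyl ring with only hydrogen there. As far as these compounds go, all three compounds also share the same core and sit at similarly high numbers, so it remains unknown whether any group at this place can move the number beyond the scatter.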